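Swapping a pyrrole for a hydroxy group

The source may hold more compounds than are shown below. What is called first, only, known or untested is meant among the compounds shown, and "the series" means these compounds.

Measured in a functional assay on HCT-116 cells (Homo sapiens) for cytotoxicity, read by scintillation counting and thymidine incorporation, with a stated time of 72 h; a higher number here means a weaker inhibitor, a lower number a stronger inhibitor:
- compound 1 `COc1cc(OC)cc(C(=CC#N)c2ccc(OC)c(NC(C)=O)c2)c1` gives 92 nM
- compound 2 `C=C(c1cc(OC)cc(OC)c1)c1ccc(OC)c(OC)c1` gives > 10000 nM
- compound 3 `CCOc1cc(C(=CC#N)c2ccc(OC)c(-n3cccc3)c2)ccc1OC` gives 49 nM

Only two of these three results are true numbers. Compound 2 gave only a limit of the assay (> 10000 nM). Compound 3 (49 nM) has compound 1 (92 nM) as its nearest neighbour, and the gap between the two lies within the usual scatter of repeated measurements, so the data do not rank them.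

The next compound to be tested is compound 4 `CCOc1cc(C(=CC#N)c2ccc(OC)c(O)c2)ccc1OC`. It keeps the rest of compound 3 but has hydroxy in place of 1H-pyrrol-1-yl on an aromatic carbon. This carbon belongs to a six-membered aromatic ring, ortho to a methoxy group and meta to a large group.

Among the compounds with values here, no measured pair isolates this kind of change, so any forecast is loose. The two true numbers, for compound 1 (92 nM) and compound 3 (49 nM), sit close together, which gives a modest basis for expecting no shift beyond the scatter in this assay. The expected change is small, a 1.2-fold lower number from compound 3 to compound 4 (0.09 log units; within the scatter), and its direction is uncertain. For compound 4 the estimated value is 40 nM, with an expected range from 8 nM to 200 nM.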

Compound 4, half-maximal inhibitory concentration: 15 nM
Compound 4: the middle estimate sits 2.7-fold (0.43 log units) above what was measured; measured number inside the range.
By their numbers in this assay, from the lowest: compound 4; then compounds 3 and 1 (each within the scatter of the next). At a limit, above all of these: compound 2.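

In this assay, putting hydroxy in place of 1H-pyrrol-1-yl on this aromatic carbon gives a 3.3-fold lower number from compound 3 to compound 4 (0.51 log units; beyond the scatter). Within the data shown here, this is the first single-place change, and it shows that the group on this carbon can move the number beyond the scatter. It also shows that the five-membered aromatic ring is not needed for a low number in this assay, since hydroxy, with 1 heavy atom against 5 and with 1 hydrogen-bond donor against 0, gives a lower one, but nothing measured here explains why the number falls.

The step changes size, ring and donor count all at once, so it cannot say which of these matters; an amine or a fluorine atom on the same carbon would help to pull them apart. Going by these compounds, it also rests on this one pair, so whether hydroxy brings a similar step on the core of compound 1, with its different alkoxy groups, remains open, as does the effect of a longer chain in place of hydroxy.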